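A few compounds are considered here, and "the series" means these few. Any claim that something is new, unique, unknown or untested is made for them only; others in the source may bear on it.

In a functional assay on NCI-H727 cells (Homo sapiens) for antiproliferative activity, with a stated time of 48 h (on this read-out lower numbers stand for stronger inhibition and higher numbers for weaker inhibition), compound 1 `CCN(CC)c1ccc(-c2cccc(OC)c2)nn1` gives > 25000 nM, which is a limit of the assay and not a number. For the measured compounds named here, the only other compound measured so far, compound 2 `CCN(CC)c1ccc(-c2ccc(C(C)=O)cc2)nn1`, gives 25000 nM in this assay. Going by the values given here, no step between measured compounds can be read from these two results, so the data offer no direct guide to how much a single change moves the read-out.

Compound 3 `CCOC(=O)c1cccc(-c2ccc(N(CC)CC)nn2)c1` keeps the core of compound 1 and differs from it in one place, with ethoxycarbonyl in place of methoxy on an aromatic carbon, meta to a large group: ethoxycarbonyl in place of methoxy on an aromatic carbon. Among the compounds with values here, compound 2 at 25000 nM is the only number available as a reference, and it lies at the top of the range seen in this assay. The expected result is therefore weak inhibition again, and a reported limit is as likely as a number. The estimated change, an at least 1.1-fold lower number from compound 1 to compound 3 (0.05 log units; that floor lies within the scatter), is small and, if it can be seen at all, is expected to run towards stronger inhibition. For compound 3 the estimated value is 22000 nM, with an expected range of 9000 nM to 40000 nM.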

Compound 3, half-maximal inhibitory concentration: 30000 nM
The estimate for compound 3 lay 1.4-fold (0.13 log units) below the measured number, and the stated range covers the measured number.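

For compound 1 and compound 3 no step can be read in this assay, because the value of compound 1 is a limit of the assay and not a number: the limit of > 25000 nM in this assay, at which 1 of the 3 values shown sits.

The compounds shown leave open how far ethoxycarbonyl in place of methoxy on an aromatic carbon moves the read-out, and whether any change to the shared core gives clearly stronger inhibition.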